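Indole substituent swap in the chlorodienone nitrile series

The source may hold more compounds than are shown below. What is called first, only, known or untested is meant among the compounds shown, and "the series" means these compounds.

Compound 3 `COc1cc(/C(Cl)=C/C=C(\C#N)C(=O)c2c[nH]c3ccc(Br)cc23)cc(OC)c1OC` gives 96500 nM in a functional assay on MCF7 cells (Homo sapiens) for cytotoxicity, read by sulforhodamine B assay, with a stated time of 48 h; on this read-out lower numbers stand for stronger inhibition of growth and higher numbers for weaker inhibition of growth. Compound 1 `COc1cc(/C(Cl)=C/C=C(\C#N)C(=O)c2c(C)[nH]c3ccccc23)cc(OC)c1OC` gives 83700 nM in this assay. Compound 2 `COc1ccc(/C(Cl)=C/C=C(\C#N)C(=O)c2c[nH]c3ccc(Br)cc23)cc1OC` reaches only a limit of the assay, > 100000 nM (the limit of > 100000 nM in this assay, at which 1 of the 3 values shown sits). Compound 3 therefore holds the higher of the two numbers, yet a 1.2-fold higher number from compound 1 to compound 3 (0.06 log units; within the scatter) lies within the scatter, and so does an at least 1.0-fold lower number from compound 2 to compound 3 (0.01 log units; that floor lies within the scatter). Compound 4 `COc1ccc2[nH]cc(C(=O)/C(C#N)=C/C=C(\Cl)c3cc(OC)c(OC)c(OC)c3)c2c1` differs from compound 3 by methoxy in place of bromo on an aromatic carbon. Among the compounds with values here, the only measured step touching the indole substituent, a 1.2-fold higher number from compound 1 to compound 3 (0.06 log units; within the scatter), moved nothing beyond the scatter, so no step beyond the scatter is expected here in this assay either, with a fair chance of a limit. Compound 4 is estimated at 90000 nM, ranging from 40000 nM to 180000 nM. The expected step is a 1.1-fold lower number from compound 3 to compound 4 (0.03 log units; within the scatter).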

Compound 4, concentration for total growth inhibition: > 100000 nM
Compound 4 gave a limit, no number (the forecaster's own chance of this, stated with the estimate: 40%); middle value at least 1.1-fold (0.04 log units) away from the limit.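

Methoxy in place of bromo on this aromatic carbon gives an at least 1.0-fold higher number from compound 3 to compound 4 (0.01 log units; that floor lies within the scatter), the first change read at this position, and it is only a floor, so its true size stays unknown. Compound 4 gives a limit and not a number. Limits now stand among the series values in this assay: the limit of > 100000 nM in this assay, at which 2 of the 4 values shown sit.

The compounds shown leave open whether any group on this aromatic carbon moves the number beyond the scatter. An amine or a carboxylic acid there would test this, as would a longer alkoxy chain.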